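The source may hold more compounds than are shown below. What is called first, only, known or untested is meant among the compounds shown, and "the series" means these compounds.

In a physicochemical assay for solubility, measured as kinetic solubility, at pH 6.5 (a higher number here means a more soluble compound, a lower number a less soluble compound), compound 2 `CCOc1ncc(-c2ccc(S(C)(=O)=O)cc2)cc1-c1ccc(OC)nc1` stands at < 1.6 ug/mL, which is a limit of the assay and not a number. Compound 1 `COc1ccc(-c2cc(-c3ccc(S(C)(=O)=O)cc3)cnc2O)cn1` gives 25 ug/mL in this assay. Going by the values given here, the only measured step is an at least 15-fold lower number from compound 1 to compound 2 (1.19 log units; beyond the scatter), with ethyl in place of hydrogen on an oxygen on an aromatic ring. Compound 3 `COc1ccc(-c2cc(-c3ccc(S(C)(=O)=O)cc3)cnc2N)cn1` drops the ethoxy of compound 2, with amino in place of ethoxy on an aromatic carbon. The measured step bears on this change only in part, since the ethyl also leaves here but amino, not oxygen, stays on the ring. The expectation rests on compound 1 at 25 ug/mL, which carries no ethyl. A large step upward is expected in this assay, estimated as an at least 9.3-fold higher number from compound 2 to compound 3 (0.97 log units; beyond the scatter). Compound 3 is estimated at 15 ug/mL, with an expected range of 4 ug/mL to 60 ug/mL.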

Compound 3, solubility: 121 ug/mL
The estimate for compound 3 lay 8.1-fold (0.91 log units) below the measured number, and the stated range ends below it.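

In this assay, amino on the aromatic carbon next to the ring nitrogen gives an at least 75-fold higher number from compound 2 to compound 3 (1.87 log units; beyond the scatter) and this is the largest step shown at this position, although its true size stays open since compound 2 sits at a limit of the assay and not at a number: the limit of < 1.6 ug/mL in this assay, at which 1 of the 3 values shown sits.
Amino in place of hydroxy still gives a 4.8-fold higher number from compound 1 to compound 3 (0.68 log units; beyond the scatter) and so this position responds to more than the removal of the ethyl: the group left on the ring also matters, by a margin beyond the scatter.
With ethoxy, hydroxy and amino, the series now has three groups at this one position.

On these data alone, whether the gain holds for a methylamino or dimethylamino group here remains open, as does the outcome with an acetamido group or a carboxylic acid.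
The compounds shown also leave open whether the step carries over when the 6-methoxypyridin-3-yl group is replaced.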